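Removing the chain methyl: half-life expected to shrink

This account rests on a few compounds, and the source may have more. Where it says the series, first, only, none or still open, it means among the compounds named here.

Compound 3 `Cc1cc(CC(C)C(=O)O)ccc1-c1noc(-c2ccc(OC(C)C)c(C(F)(F)F)c2)n1` sits second highest of three in an in vivo ADME assay on the whole organism (strain Sprague-Dawley) for metabolic stability, with Rattus norvegicus as the target (a higher number here means that the compound lasts longer, a lower number that the compound disappears faster), where compound 3 gives 1.7 h; the nearest neighbour is compound 2 `Cc1cc(CCC(=O)O)ccc1-c1noc(-c2ccc(OC(C)C)c(C#N)c2)n1`, which gives 0.7 h, and the furthest is compound 1 `Cc1cc([C@@H]2C[C@H]2C(=O)O)ccc1-c1noc(-c2ccc(OC(C)C)c(C(F)(F)F)c2)n1`, which gives 6.3 h. Compound 4 `Cc1cc(CCC(=O)O)ccc1-c1noc(-c2ccc(OC(C)C)c(C(F)(F)F)c2)n1` differs from compound 3 by hydrogen in place of methyl on a saturated chain carbon bound to a carbonyl carbon and a saturated chain carbon. Going by the values given here, no measured step repeats this exact change. Among the compounds with values here, the only single-place step, a 3.7-fold lower number from compound 1 to compound 3 (0.57 log units; beyond the scatter), concerns a different part of the chain, while compound 2 shares the plain chain of compound 4 but carries a nitrile rather than trifluoromethyl. The half-life of compound 4 is therefore expected to fall somewhat, roughly a 1.7-fold lower number from compound 3 to compound 4 (0.23 log units; within the scatter). Compound 4 is estimated at 1 h, within 0.4 h to 2.5 h.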

Compound 4, half-life: 1.1 h
Estimate against measurement, compound 4: 1.1-fold (0.04 log units) below; measured number inside the range.
By their numbers in this assay, from the lowest: compounds 2, 4 and 3 (each within the scatter of the next, the first and the last beyond it); then compound 1.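

In this assay, hydrogen in place of methyl on this saturated chain carbon gives a 1.5-fold lower number from compound 3 to compound 4 (0.19 log units; within the scatter), so the methyl alone does not separate these two compounds. Swapping the other end of the molecule gives a 1.6-fold higher number from compound 2 to compound 4 (0.20 log units; within the scatter), also without leaving the scatter. Only the 2-carboxycyclopropyl group stands apart, with a 5.7-fold lower number from compound 1 to compound 4 (0.76 log units; beyond the scatter) for its replacement by 2-carboxyethyl, and nothing available explains these results. The compounds shown leave open whether a longer chain, or an amide in place of the carboxylic acid, would hold the half-life near that of compound 1.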